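This account rests on a few compounds, and the source may have more. Where it says the series, first, only, none or still open, it means among the compounds named here.

Measured compounds:
- compound 1, `CCOC1Oc2ccccc2C(=O)/C1=C\Nc1ccc(S(N)(=O)=O)cc1`: 90600 nM
- compound 2, `O=c1c(C2Nc3ccccc3S(=O)(=O)N2)coc2ccc(Br)cc12`: 21 nM
- compound 3, `CCOC1Oc2ccc(F)cc2C(=O)/C1=C/Nc1ccc(S(=O)(=O)Nc2nnc(C)s2)cc1`: 10 nM

In an assay on isolated protein for inhibition of Intestinal-type alkaline phosphatase (Bos taurus), read by spectrophotometry, with stated times of 10 min and 30 min (on this read-out lower numbers stand for stronger inhibition and higher numbers for weaker inhibition), compound 3 gives the lowest number of the three; compound 2 stands nearest, and compound 1 sits far above both. Compound 1 and compound 3 differ in more than one place, so the part played by the single fluorine cannot be read from the values shown.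

Compound 4, `CCOC1Oc2ccccc2C(=O)/C1=C/Nc1ccc(S(=O)(=O)Nc2nnc(C)s2)cc1`, is the next member: hydrogen in place of fluoro on an aromatic carbon. Going by the values given here, no measured pair in this set isolates that change. With only a fluorine removed from the fused aromatic ring and the sulfonamide side left untouched, the step in this assay is expected to be small, most likely toward a somewhat higher number, and probably not beyond the usual scatter.

Compound 4 is therefore estimated at 18 nM, with a plausible range of 5 nM to 70 nM, a step of a 1.8-fold higher number from compound 3 to compound 4 (0.26 log units; within the scatter) expected.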

Compound 4, inhibition constant: 85 nM
Compound 4: middle estimate off by 4.7-fold (0.67 log units), on the low side; the measured number lies above the stated range.
By their numbers in this assay, from the lowest: compound 3; then compound 2; then compound 4; then compound 1.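

In this assay the fluoro on this aromatic carbon carries real weight: hydrogen in its place gives an 8.5-fold higher number from compound 3 to compound 4 (0.93 log units; beyond the scatter) with the rest of the structure unchanged. Going by these compounds alone, this is the first comparison that differs in one place only, so this position of the fused system can now be said to affect the read-out, at least with the methylthiadiazole sulfonamide side held fixed. Nothing measured here speaks to why the loss of fluoro has a step of this size.

On these data alone, whether fluoro is the best group at this carbon remains open, as a chloro, methyl or methoxy group there would show whether the step is specific to fluoro or holds for any group other than hydrogen. Also open, as far as these compounds go, is whether the same change would give a step of like size on the plain sulfonamide side of compound 1.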